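The source may hold more compounds than are shown below. What is called first, only, known or untested is meant among the compounds shown, and "the series" means these compounds.

Measured compounds:
- compound 1 `COc1ccc(C(=O)Nc2cccc(-c3oc4cc(-c5ccc(F)cc5)ccc4c(=O)c3O)c2)cc1`: 5490 nM
- compound 2 `O=C(Nc1cccc(-c2oc3cc(-c4ccc(F)cc4)ccc3c(=O)c2O)c1)c1ccc(C(F)(F)F)cc1`: 7350 nM

Both numbers come from a functional assay on HCC1937 cells (Homo sapiens) for antiproliferative activity, read by CCK-8 assay, with a stated time of 72 h; on this read-out higher numbers stand for weaker inhibition and lower numbers for stronger inhibition. Compound 2 holds the higher of the two numbers, but its gap to compound 1, a 1.3-fold higher number from compound 1 to compound 2 (0.13 log units; within the scatter), is within the scatter, so the two compounds cannot be told apart on this read-out.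

Compound 3 `Cc1cccc(C(=O)Nc2cccc(-c3oc4cc(-c5ccc(F)cc5)ccc4c(=O)c3O)c2)c1` has not been measured. It differs from compound 2 in one place: 3-methylphenyl in place of 4-(trifluoromethyl)phenyl on a carbonyl carbon. For the measured compounds named here, the only measured step, from compound 1 to compound 2, swapped one group for another at the same position and changed nothing beyond the scatter. Going by the values given here, no measured pair shows a methyl group or a change of position on this ring, so the expectation rests on that single step alone. Compound 3 is therefore expected to stay close to compound 2, with a step of a 1.2-fold lower number from compound 2 to compound 3 (0.09 log units; within the scatter) in this assay, and an estimated value of 6000 nM, within a range from 2500 nM to 14000 nM.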

Compound 3, half-maximal inhibitory concentration: 8030 nM
Beside the measured number, compound 3's estimate is 1.3-fold (0.13 log units) below it; the measured number falls inside the stated range.
By their numbers in this assay, from the lowest: compounds 1, 2 and 3 (each within the scatter of the next).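

In this assay, the group on this carbonyl carbon now comes in three forms. Replacing 4-(trifluoromethyl)phenyl with 3-methylphenyl gives a 1.1-fold higher number from compound 2 to compound 3 (0.04 log units; within the scatter), and replacing 4-methoxyphenyl with 3-methylphenyl gives a 1.5-fold higher number from compound 1 to compound 3 (0.17 log units; within the scatter). For the compounds shown here, the earlier step compared only two groups, whereas these steps add a methyl group and a differently numbered ring position, and the three compounds still cannot be told apart; no measurement at hand offers an explanation for this.

All three compounds keep a substituted phenyl ring on this carbonyl carbon. On these data alone, whether an amine or a carboxylic acid on that ring, or a longer chain in its place, would move the number beyond the scatter remains open.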